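Aryl swap on the ring nitrogen: outlook for compound 4

The source may hold more compounds than are shown below. What is called first, only, known or untested is meant among the compounds shown, and "the series" means these compounds.

Measured so far in a functional assay on HepG2 cells (Homo sapiens) for inhibition, read by MTT assay, with a stated time of 72 h; on this read-out lower numbers stand for stronger inhibition and higher numbers for weaker inhibition:
compound 1 `O=C(Nc1cccc(OCc2cn(-c3ccccc3)nn2)c1)Nc1ccc(Cl)c(C(F)(F)F)c1` gives 1780 nM
compound 2 `N#Cc1cccc(-n2cc(COc3cccc(NC(=O)Nc4ccc(Cl)c(C(F)(F)F)c4)c3)nn2)c1` gives 2760 nM
compound 3 `O=C(Nc1cccc(OCc2cn(-c3ccccc3F)nn2)c1)Nc1ccc(Cl)c(C(F)(F)F)c1` gives 1520 nM

Compound 2 has the highest of the three numbers, but its neighbours are close: a 1.6-fold higher number from compound 1 to compound 2 (0.19 log units; within the scatter) and a 1.8-fold lower number from compound 2 to compound 3 (0.26 log units; within the scatter) both stay inside the scatter, so the three compounds are not separated on this read-out.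

Compound 4 `O=C(Nc1cccc(OCc2cn(-c3ccccc3Br)nn2)c1)Nc1ccc(Cl)c(C(F)(F)F)c1` is the next member. Its difference from compound 2 is 2-bromophenyl in place of 3-cyanophenyl on an aromatic nitrogen.

The step that bears most directly on this change is a 1.8-fold lower number from compound 2 to compound 3 (0.26 log units; within the scatter), where another 2-substituted phenyl replaced the 3-cyanophenyl and the number moved down only within the scatter. The related step of a 1.2-fold lower number from compound 1 to compound 3 (0.07 log units; within the scatter), adding a fluoro to the phenyl, also stayed within the scatter. Nothing here points to a shift beyond the usual spread; a number near those of compound 1 and compound 3 is the plain expectation.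

In this assay compound 4 is therefore estimated at 1700 nM, with a range from 800 nM to 3600 nM. The expected step is a 1.6-fold lower number from compound 2 to compound 4 (0.21 log units; within the scatter), a change not expected to exceed the scatter.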

Compound 4, half-maximal inhibitory concentration: 2810 nM
For compound 4 the middle estimate is 1.7-fold (0.22 log units) below the measured one; low and high end bracket the measured number.
By their numbers in this assay, from the lowest: compounds 3, 1, 2 and 4 (each within the scatter of the next).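

Bromo now stands on the phenyl ring, and in this assay the exchange of the whole aryl group gives a 1.0-fold higher number from compound 2 to compound 4 (0.01 log units; within the scatter), so 2-bromophenyl and 3-cyanophenyl are not told apart on this read-out. On the same ring, the halogen exchange gives a 1.8-fold higher number from compound 3 to compound 4 (0.27 log units; within the scatter) and bromo in place of hydrogen gives a 1.6-fold higher number from compound 1 to compound 4 (0.20 log units; within the scatter), so hydrogen, fluoro and bromo are not separated here either. With this result, every listed step among compound 1, compound 2, compound 3 and compound 4 stays within the scatter, and none of these compounds goes against this flat picture of the aryl group on the aromatic nitrogen. No measurement at hand accounts for this flat picture.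

Still open, going by these compounds, is whether a phenyl ring carrying an amine or a carboxylic acid, or a longer alkyl chain in place of the phenyl ring, would give a number beyond the scatter in this assay. The compounds shown also leave open whether bromo elsewhere on the phenyl ring would keep the number within the scatter of compound 4.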